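Compound 4 Measured Against Three Half-Life Benchmarks

The source may hold more compounds than are shown below. What is called first, only, known or untested is meant among the compounds shown, and "the series" means these compounds.

Three compounds that share one core have been examined in an ADME assay on microsomes from liver (Homo sapiens) for metabolic stability, read by LC-MS, using NADPH, tested at 5 uM; a higher number here means that the compound lasts longer, a lower number that the compound disappears faster. Compound 1 `NC(=O)c1cn(Cc2nnc(-c3cc(S(N)(=O)=O)c(SCc4ccccc4)cc3Cl)o2)nn1` gives 0.435 h in this assay. Compound 2 `NCc1nnc(-c2cc(S(N)(=O)=O)c(SCc3ccccc3)cc2Cl)o1` gives 0.263 h. Compound 3 `NS(=O)(=O)c1cc(-c2nnc(CNS(=O)(=O)c3ccc(Cl)cc3)o2)c(Cl)cc1SCc1ccccc1` gives 0.197 h, the lowest of the three numbers; its nearest neighbour is compound 2, and the gap to compound 1 is the only one that lies beyond the scatter.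

The steps among these compounds all concern the group on the saturated chain carbon bound to the aromatic carbon of the shared core. The step of a 1.7-fold lower number from compound 1 to compound 2 (0.22 log units; within the scatter) stays within the scatter, the step of a 2.2-fold lower number from compound 1 to compound 3 (0.34 log units; beyond the scatter) is modest, and the step of a 1.3-fold lower number from compound 2 to compound 3 (0.13 log units; within the scatter) again stays within the scatter.

Compound 4 `NS(=O)(=O)c1cc(-c2nnc(/C=C/c3cccc(Cl)c3)o2)c(Cl)cc1SCc1ccccc1` goes further than any of these: here (2-(3-chlorophenyl)ethenyl in place of (((4-chlorophenyl)sulfonyl)amino)methyl on an aromatic carbon). Among the measured compounds shown here, no measured step removes the chain itself or introduces a double bond outside aromatic rings, so the bearing of the earlier steps is indirect. Since the three measured values themselves span only a modest range, the step of a 1.1-fold higher number from compound 3 to compound 4 (0.05 log units; within the scatter) is expected to be small, with no clear direction beyond the scatter. Compound 4 is therefore estimated at 0.22 h in this assay, with a plausible range from 0.1 h to 0.48 h.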

Compound 4, half-life: 0.352 h
Estimate against measurement, compound 4: 1.6-fold (0.20 log units) below; the measured number falls inside the stated range.
By their numbers in this assay, from the lowest: compounds 3, 2, 4 and 1 (each within the scatter of the next, the first and the last beyond it).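

In this assay, 2-(3-chlorophenyl)ethenyl on the aromatic carbon of the five-membered ring gives a 1.8-fold higher number from compound 3 to compound 4 (0.25 log units; within the scatter), a 1.3-fold higher number from compound 2 to compound 4 (0.13 log units; within the scatter) and a 1.2-fold lower number from compound 1 to compound 4 (0.09 log units; within the scatter), so compound 4 lies within the scatter of each earlier compound. The earlier compounds shown here varied only the group on the saturated chain carbon, whereas compound 4 shows that the whole chain with its nitrogen can give way to a group with 0 hydrogen-bond donors, 0 hydrogen-bond acceptors and a double bond outside aromatic rings, without a step beyond the scatter from any of the three. Nothing shown here offers a reason for these numbers.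

The compounds shown leave open how a 2-(3-chlorophenyl)ethyl group, with a saturated chain in place of the double bond, a 2-phenylethenyl group without the chlorine, or a carboxylic acid on this same ring carbon would read in this assay. They also leave open what a change elsewhere would do, as all four compounds keep the same benzylthio group, and a methylthio group in its place would test that part of the shared core.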